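Chloro for Hydrogen on a Cytotoxicity-Silent Core

The source may hold more compounds than are shown below. What is called first, only, known or untested is meant among the compounds shown, and "the series" means these compounds.

Compound 1 `ClCc1ccccc1Cn1cnc2ncnc(Cl)c21` was examined in a functional assay on NCI-H226 cells (Homo sapiens) for cytotoxicity, read by sulforhodamine B assay, with a stated time of 48 h; a higher number here means that more compound is tolerated, a lower number that less compound is tolerated. In this assay compound 1 reaches only a limit of the assay, > 100000 nM. Compound 2 `Nc1nc(Cl)c2ncn(Cc3cccc(CCl)c3)c2n1`, the other measured member of the set, gives in this assay likewise a limit, > 100000 nM. Among the measured compounds shown here, both measured values therefore sit at the same edge of the measured range, (the limit of > 100000 nM in this assay, at which 2 of the 2 values shown sit), and compound 1 stands exactly where its single neighbour stands, tolerated up to the highest concentration tested.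

Compound 3 `ClCc1ccccc1Cn1cnc2nc(Cl)nc(Cl)c21` remains to be measured. It differs from compound 1 by chloro in place of hydrogen on an aromatic carbon. For the measured compounds named here, no step between measured compounds exists in this set, so nothing shows what such a change does in this assay. For compound 3 the expected step is a number no higher from compound 1 to compound 3 (the limit leaves the size open), none beyond the scatter. Compound 3 is thus estimated at 100000 nM, between 40000 nM and 250000 nM, and most probably the assay again reports only a limit.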

Compound 3, concentration lethal to 50% of the cells: 28200 nM
The estimate for compound 3 lay 3.5-fold (0.55 log units) above the measured number, and the stated range ends above it.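

In this assay, among the compounds shown here, chloro in place of hydrogen on the aromatic carbon between two ring nitrogen atoms gives an at least 3.5-fold lower number from compound 1 to compound 3 (0.54 log units; beyond the scatter), the first step in the set that can be read at all. It shows that this position is not silent: on the core of compound 1, this single added chloro is enough to bring a number inside the measured range, where less compound is tolerated. Compound 3 is the only compound shown that has left the edge of that range: the limit of > 100000 nM in this assay, at which 2 of the 3 values shown sit.

On these data alone, the true size of the step remains open, as the value of compound 1 is only a limit. As far as these compounds go, whether the change depends on chloro itself, or whether fluoro or a methoxy group on the same carbon would do the same, also remains open.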